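This account rests on a few compounds, and the source may have more. Where it says the series, first, only, none or still open, it means among the compounds named here.

Working notes on the series.

Among the measured compounds shown here, compound 2 (`COc1ccc(C(=O)c2ccc3c(ccn3Cc3ccc(C(=O)NO)cc3)c2)cc1OC`) stands lowest of the two numbers so far in an assay on isolated protein for inhibition of histone deacetylase 8 (Homo sapiens); a higher number here means a weaker inhibitor, a lower number a stronger inhibitor: compound 2 gives 756 nM. For the measured compounds named here, the only other measured member is compound 1 (`COc1cc(C(=O)c2ccc3c(ccn3S(=O)(=O)c3ccc(/C=C/C(=O)NO)cc3)c2)cc(OC)c1OC`), and in this assay compound 1 gives 5340 nM, a gap to compound 2 that lies beyond the scatter. Going by the values given here, compound 1 and compound 2 differ in more than one place, so no single-change step between measured compounds is at hand, and nothing in the pair says which of their differences carries the gap.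

Compound 3 (`O=C(NO)c1ccc(Cn2ccc3cc(C(=O)c4ccc(F)cc4)ccc32)cc1`) is not yet measured. Relative to compound 2 the change is 4-fluorophenyl in place of 3,4-dimethoxyphenyl on a carbonyl carbon. Nothing measured in the series speaks to this change; it keeps the part of compound 2 that compound 1 does not share. The working expectation is a step from compound 2 to compound 3 of a 1.2-fold higher number from compound 2 to compound 3 (0.08 log units; within the scatter) in this assay, that is, none beyond the scatter in either direction. The estimate for compound 3 in this assay is 900 nM, with a range from 350 nM to 2500 nM.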

Compound 3, half-maximal inhibitory concentration: 1240 nM
Compound 3: middle estimate off by 1.4-fold (0.14 log units), on the low side, within the range that was stated.
By their numbers in this assay, from the lowest: compounds 2 and 3 (each within the scatter of the next); then compound 1.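

Among the compounds shown here, on the carbonyl carbon, 4-fluorophenyl in place of 3,4-dimethoxyphenyl supplies the first single-change step, and in this assay it reads a 1.6-fold higher number from compound 2 to compound 3 (0.21 log units; within the scatter), so this one exchange leaves the two numbers within the scatter of each other. The group that enters has 7 heavy atoms and 0 hydrogen-bond acceptors, against 10 heavy atoms and 2 hydrogen-bond acceptors in the group that leaves, and in this pair those differences come with no step beyond the scatter. No measurement at hand bears on the reason for the size of this step.

As far as these compounds go, it remains open whether the same holds on this carbonyl carbon for groups of another kind, such as an unsubstituted phenyl, a pyridine ring, or a phenyl carrying a dimethylamino group or a carboxylic acid, since the two groups compared here are both substituted phenyl rings. For the compounds shown here, it also remains open which of the differences between compound 1 and the other two compounds carries the gap seen in their printed values, as no single-change step connects compound 1 to either.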